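Cyclobutyl in place of ethyl on compound 3

The source may report more compounds than this note shows. Statements on the series, on what has been measured and on what is new or still open speak of the compounds shown alone.

In a physicochemical assay for solubility, read by HPLC, in phosphate buffer, measured as kinetic solubility, at pH 7.4 (a lower number here means a less soluble compound, a higher number a more soluble compound), compound 1 (`CCC(=O)c1cc(-c2ccc(C)cc2)n(-c2ccc(S(N)(=O)=O)cc2)c1C`) gives 1000 nM and compound 2 (`CCOC(=O)c1cc(-c2ccc(F)cc2)n(-c2ccc(I)cc2)c1`) gives 300 nM as its reading. Compound 3 (`CCCC(=O)c1cc(-c2ccc(S(N)(=O)=O)cc2)n(-c2ccc(Cl)cc2)n1`) reaches 25800 nM as the highest of the three numbers, beyond the scatter from both others. No measured pair differs in one place, so no shown step sizes the next change. Compound 4 (`NS(=O)(=O)c1ccc(-c2cc(C(=O)CC3CCC3)nn2-c2ccc(Cl)cc2)cc1`) carries cyclobutyl in place of ethyl on a saturated chain carbon bound to a carbonyl carbon. In this assay a modest move toward a lower number is expected, since compound 3 at 25800 nM stands well clear of the other two. The expected change is a 3.2-fold lower number from compound 3 to compound 4 (0.51 log units; beyond the scatter) as an estimate. Compound 4 is estimated at 8000 nM with an expected range from 2500 nM to 20000 nM for this reading.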

Compound 4, solubility: 4300 nM
Estimate against measurement, compound 4: 1.9-fold (0.27 log units) above, and the stated range covers the measured number.
By their numbers in this assay, from the lowest: compound 2; then compound 1; then compound 4; then compound 3.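

In this assay, the saturated chain carbon bound to a carbonyl carbon now has its first sized change: cyclobutyl in place of ethyl gives a 6.0-fold lower number from compound 3 to compound 4 (0.78 log units; beyond the scatter) and counts as a modest step, beyond the scatter. Within the data shown here, the position therefore responds to a purely carbon swap, which no earlier pair could show. Nothing shown accounts for the step.

Still open, as far as these compounds go, is how an amine or a carboxylic acid at this place would read against cyclobutyl. Also open, from the compounds shown here alone, is whether the same change on the core of compound 1 gives a step of similar size.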